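Amide swap on a scaffold that has not yet shown inhibition

The compounds below may be only part of what the source reports. "The series", "measured", "known", "first", "only" and "open" are said of these compounds alone.

Compound 1 `Cc1c(C(=O)N2CCOCC2)oc2ccc(Nc3ncnc4ccc(Cl)nc34)cc12` — > 10000 nM
Compound 2 `COC(=O)c1cccc(C#Cc2ccccc2Nc2ncnc3ccc(Cl)nc23)c1` — > 10000 nM

Of the compounds shown here, two have been tested in an assay on isolated protein for inhibition of MAP kinase-interacting serine/threonine-protein kinase 1 (Homo sapiens), read by HTRF, in the presence of a further agent that is not named here; on this read-out higher numbers stand for weaker inhibition and lower numbers for stronger inhibition. Compound 1 gives > 10000 nM in this assay, which is a limit of the assay and not a number. Compound 2 likewise reaches only a limit, > 10000 nM. Both readings sit at the limit of > 10000 nM in this assay, at which 2 of the 2 values shown sit, so compound 1 cannot be ranked against anything measured. Compound 3 `CNC(=O)c1oc2ccc(Nc3ncnc4ccc(Cl)nc34)cc2c1C` differs from compound 1 by methylamino in place of morpholin-4-yl on a carbonyl carbon. Among the measured compounds shown here, no measured pair shows what this change does, and no shift beyond the scatter is expected. Compound 3 is estimated at 15000 nM, within 3000 nM to 60000 nM. This expectation corresponds to a step that the limit leaves unreadable from compound 1 to compound 3.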

Compound 3, half-maximal inhibitory concentration: > 10000 nM
Compound 3 ended at the assay's limit; the forecaster's own chance of this, stated with the estimate: 80%; the middle value is on the limit's open side.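

Compound 3 reads > 10000 nM, which is a limit of the assay. Among the compounds shown here, compound 1 also stands at a limit, so no step between compound 1 and compound 3 can be read. From the compounds shown here alone, whether methylamino or morpholin-4-yl gives stronger inhibition stays open.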